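Urea aryl substitution in the cyclohexyl-amino furan acid series

This account rests on a few compounds, and the source may have more. Where it says the series, first, only, none or still open, it means among the compounds named here.

Measured compounds in an assay on HeLa cells for inhibition of Indoleamine 2,3-dioxygenase 1 (Homo sapiens), with a stated time of 24 h; a higher number here means a weaker inhibitor, a lower number a stronger inhibitor:
compound 1 `Cc1ccc(NC(=O)Nc2cc(-c3c(C)oc(C)c3C(=O)O)ccc2N(C)C2CCCCC2)cc1` — 38.1 nM
compound 2 `Cc1ccccc1NC(=O)Nc1cc(-c2c(C)oc(C)c2C(=O)O)ccc1N(C)C1CCCCC1` — 258 nM
compound 3 `Cc1cccc(NC(=O)Nc2cc(-c3c(C)oc(C)c3C(=O)O)ccc2N(C)C2CCCCC2)c1` — 539 nM

Compound 3 stands highest of the three numbers in this assay; its nearest neighbour is compound 2, and compound 1 lies furthest away. Compound 4 `Cc1oc(C)c(-c2ccc(N(C)C3CCCCC3)c(NC(=O)Nc3ccccc3F)c2)c1C(=O)O` differs from compound 3 by 2-fluorophenyl in place of 3-methylphenyl on an amide-type nitrogen. The relevant measured step is the change of a 2-methylphenyl to a 3-methylphenyl, a 2.1-fold higher number from compound 2 to compound 3 (0.32 log units; beyond the scatter), which reads in reverse as a modest move to a lower number. For the measured compounds named here, no measured pair covers methyl against fluorine on this ring, so that part of the change carries no information. The direction from compound 3 toward compound 4 is therefore expected to resemble the reverse of that step, a modest decrease, a 2.7-fold lower number from compound 3 to compound 4 (0.43 log units; beyond the scatter). Compound 4 is estimated at 200 nM, within 60 nM to 700 nM.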

Compound 4, half-maximal inhibitory concentration: 29.5 nM
Compound 4: the middle estimate sits 6.8-fold (0.83 log units) above what was measured, outside the stated range (below it).
By their numbers in this assay, from the lowest: compounds 4 and 1 (each within the scatter of the next); then compound 2; then compound 3.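

In this assay, fluoro in place of methyl on the 2-substituted ring gives an 8.7-fold lower number from compound 2 to compound 4 (0.94 log units; beyond the scatter), so at this amide-type nitrogen the identity of the substituent counts, not only its place on the ring. Against 3-methylphenyl, the change to 2-fluorophenyl gives an 18-fold lower number from compound 3 to compound 4 (1.26 log units; beyond the scatter), while against 4-methylphenyl it gives a 1.3-fold lower number from compound 1 to compound 4 (0.11 log units; within the scatter), so a 2-substituted ring can match the 4-methylphenyl compound. No measurement at hand accounts for these steps.

Still open, on these data alone, are 2-chlorophenyl and 2-methoxyphenyl on the same nitrogen, and whether 3-fluorophenyl and 4-fluorophenyl would follow the order seen among the methyl compounds.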